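The compounds below may be only part of what the source reports. "The series", "measured", "known", "first", "only" and "open" are said of these compounds alone.

Compound 1 `CCCCCCCCCCCCC#Cc1cn([C@H]2CC[C@@H](CO)O2)c(=O)[nH]c1=O` is the starting point. In an ADME assay on cells (Fibroblast, Homo sapiens) for cytotoxicity, read by MTT assay (on this read-out lower numbers stand for higher toxicity in this test and higher numbers for lower toxicity in this test), compound 1 gives > 100 ug/mL, which is a limit of the test rather than a measured number. Compound 2 `CCCCCCCCC#Cc1cn([C@H]2CC[C@@H](CO)O2)c(=O)[nH]c1=O` differs from it by hydrogen in place of butyl on a saturated chain carbon, eight bonds along the chain from a triple-bonded carbon. In this assay compound 2 gives > 100 ug/mL, again a limit. The step that the two limits leave unreadable from compound 1 to compound 2 therefore cannot be read. What the two values share is the limit of > 100 ug/mL in this assay, at which 2 of the 2 values shown sit. Compound 3 `CCCCCCCCCCCCC#Cc1cn(C2CC(F)C(CO)O2)c(=O)[nH]c1=O` carries a different change: 4-fluoro-5-(hydroxymethyl)oxolan-2-yl in place of 5-(hydroxymethyl)oxolan-2-yl on an aromatic nitrogen. Among the compounds with values here, no measured step touches this part of the molecule, and the only step available is unreadable. The step expected a number no higher from compound 1 to compound 3 (the limit leaves the size open) is none beyond the scatter. The estimate for compound 3 is 100 ug/mL, between 50 ug/mL and 200 ug/mL, most likely reported once more only as a limit.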

Compound 3, half-maximal cytotoxic concentration: > 100 ug/mL
Compound 3: a limit, no number (the forecaster's own chance of this, stated with the estimate: 85%); the middle value sits exactly at the limit.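

Compound 3 gives a limit, as compound 1 does, so no step between them can be read: the limit of > 100 ug/mL in this assay, at which 3 of the 3 values shown sit.

The compounds shown leave open whether the 4-fluoro-5-(hydroxymethyl)oxolan-2-yl group or a change in chain length alters the result in this assay at all.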